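Cytotoxicity of Three Biaryl Amides and a Dichloro Analogue

The compounds below may be only part of what the source reports. "The series", "measured", "known", "first", "only" and "open" are said of these compounds alone.

compound 1 `CC(C)N(Cc1cccc(OCCCCCC(=O)O)c1)C(=O)c1ccc(-c2ccncc2)cc1` — an ADME assay on BJ cells (Homo sapiens) for cytotoxicity, read by CellTiter-Glo and resazurin assay, with a stated time of 72 h; a higher number here means that more compound is needed for the effect, a lower number that less compound is needed: > 26000 nM
compound 2 `CC(C)Oc1cccc(-c2ccc(C(=O)N(Cc3cccc(OCCCCCC(=O)O)c3)C(C)C)cc2)c1` — this assay: > 26000 nM
compound 3 `CCOc1cccc(-c2ccc(C(=O)N(Cc3cccc(OCCCCCC(=O)O)c3)C(C)C)cc2)c1` — this assay: > 20800 nM

The value of compound 1 is a limit of the assay, not a number. The value of compound 2 is likewise a limit. The value of compound 3 is also a limit. Compound 3 stands at the limit of > 20800 nM in this assay, at which 1 of the 3 values shown sits, while the other two values sit at the limit of > 26000 nM in this assay, at which 2 of the 3 values shown sit. None of the three steps can be read: a step that the two limits leave unreadable from compound 1 to compound 2, a step that the two limits leave unreadable from compound 1 to compound 3 and a step that the two limits leave unreadable from compound 2 to compound 3 all lie between limits.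

Compound 4 `CC(C)N(Cc1cccc(OCCCCCC(=O)O)c1)C(=O)c1ccc(-c2ccc(Cl)c(Cl)c2)cc1` differs from compound 3 in one place: 3,4-dichlorophenyl in place of 3-ethoxyphenyl on an aromatic carbon. Among the compounds with values here, no measured step bears readably on this change, since every value so far is a limit. Compound 4 is therefore expected to sit near the same limit, with a step estimated as a step that the limit leaves unreadable from compound 3 to compound 4. The estimate for compound 4 in this assay is 26000 nM, with a range from 8000 nM to 60000 nM.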

Compound 4, half-maximal effective concentration: > 26000 nM
Compound 4: a limit, no number; the forecaster's own chance of this, stated with the estimate: 70%; the middle value lies on the limit itself.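

In this assay compound 4 gives > 26000 nM, which is a limit and not a number. All four values are limits, so no new step can be read between compound 4 and compound 1, compound 2 or compound 3. The compounds shown leave open at what concentration any of them would produce the effect, and whether exchanging the group on the aromatic carbon would change that concentration.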